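The source may report more compounds than this note shows. Statements on the series, on what has been measured and on what is new or still open speak of the compounds shown alone.

In an ADME assay on Akata cells (Homo sapiens) for cytotoxicity (on this read-out lower numbers stand for higher toxicity in this test and higher numbers for lower toxicity in this test), compound 1 `Nc1nc2c(ncn2/C=C2\C[C@@H]2[C@H](O)CO)c(=O)[nH]1` reads 67000 nM while compound 2 `Nc1ncnc2c1ncn2/C=C1/C[C@H]1[C@H](O)CO` reads 93500 nM and these two numbers lie within the usual scatter of each other. Going by the values given here, compound 1 thus stands level with the only other compound measured so far. Compound 3 `Nc1nc2c(ncn2/C=C2\C[C@@H]2[C@@H](O)CO)c(=O)[nH]1` is compound 1 with a single change: the two compounds have the same atoms and bonds and differ only in configuration as drawn: 1 of 3 stereo elements differ; a stereocentre at a saturated chain carbon is drawn S in compound 1 and R in compound 3 and nothing else differs. Among the compounds with values here, no measured pair here shows what such a switch does in this assay and the two measured compounds give no guide to its direction. Starting from compound 1 at 67000 nM the expectation is no shift beyond the scatter, up or down. The estimated step is a 1.1-fold higher number from compound 1 to compound 3 (0.05 log units; within the scatter) and it could fall on either side. For compound 3 the estimate is 75000 nM with values between 35000 nM and 150000 nM as the expected range.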

Compound 3, half-maximal cytotoxic concentration: 61000 nM
For compound 3 the middle estimate is 1.2-fold (0.09 log units) above the measured one; the measured number falls inside the stated range.
By their numbers in this assay, from the lowest: compounds 3, 1 and 2 (each within the scatter of the next).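

Going by these compounds alone, this is the first measured pair that isolates a stereo switch: in this assay, turning the stereocentre at a saturated chain carbon from S to R gives a 1.1-fold lower number from compound 1 to compound 3 (0.04 log units; within the scatter). The two compounds therefore stand level, so at this position and on this core, the drawn configuration at that carbon makes no difference that can be told apart from repeat-to-repeat scatter. The pair can be read as a test of that one stereocentre alone for a simple reason: the fact that compounds 1 and 3 differ only in the configuration as drawn.

The compounds shown leave open whether the other two stereo elements would behave the same way, and whether this holds on other cores. They also leave open whether an amine or a longer chain at that saturated chain carbon would shift the number beyond the scatter.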